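Hydroxy for Chloro on Two Different Cores

The source may report more compounds than this note shows. Statements on the series, on what has been measured and on what is new or still open speak of the compounds shown alone.

Compound 2 `O[C@H]1C[C@@H](Cn2cnc3c(Cl)ncnc32)c2ccccc21` and compound 1 `Oc1ncnc2c1ncn2C[C@@H]1C[C@H](O)c2ccccc21` share one core and differ by hydroxy in place of chloro on an aromatic carbon. In an ADME assay on L1210/0 cells (Mus musculus) for cytotoxicity, with a stated time of 48 h (a higher number here means a weaker inhibitor, a lower number a stronger inhibitor), compound 2 gives > 200000 nM, which is a limit of the assay and not a number. Compound 1 gives > 200000 nM, again a limit. The step that the two limits leave unreadable from compound 2 to compound 1 therefore has no readable size. Compound 3 `CC1(C)[C@@H](Cn2cnc3c(Cl)nc(N)nc32)CC[C@@]1(C)CO` stands on another core; the difference between the two cores is not broken down here. In this assay, for the measured compounds named here, compound 3 gives 50000 nM, the only plain number among the three measured values. The other two sit at the limit of > 200000 nM in this assay, at which 2 of the 3 values shown sit. Compound 4 `CC1(C)[C@@H](Cn2cnc3c(O)nc(N)nc32)CC[C@@]1(C)CO` is the unmeasured partner of compound 3 and differs from it by hydroxy in place of chloro on an aromatic carbon; this is the same kind of change as before, though here the place is also meta to an amino group. The step of a 3.0-fold higher number from compound 3 to compound 4 (0.48 log units; beyond the scatter) is expected, with the hydroxy partner tending toward the limit, resting on (the limit of > 200000 nM in this assay, at which 2 of the 3 values shown sit). Compound 4 is estimated at 150000 nM, between 40000 nM and 500000 nM.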

Compound 4, half-maximal inhibitory concentration: > 200000 nM
Compound 4 ended at the assay's limit; the forecaster's own chance of this, stated with the estimate: 60%; middle value at least 1.3-fold (0.12 log units) from the limit.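

In this assay, putting hydroxy in place of chloro gives an at least 4.0-fold higher number from compound 3 to compound 4 (0.60 log units; beyond the scatter), so on the core of compound 3 the change raises the number beyond the scatter. From the compounds shown here alone, compound 4 gives > 200000 nM, which is a limit of the assay and not a number, so the full size of this step stays unknown. The same change on the core of compound 2 cannot be read, so this pair neither supports nor contradicts the step on the other core, because both of its compounds sit at the limit: the limit of > 200000 nM in this assay, at which 3 of the 4 values shown sit.

Open, going by these compounds, is how a methoxy group or a thiol in place of chloro would read on the core of compound 3. Also open, on these data alone, is whether hydroxy for chloro changes anything on the core of compound 2.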